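Aryl swap on the shared core: expected maximal response

The source may report more compounds than this note shows. Statements on the series, on what has been measured and on what is new or still open speak of the compounds shown alone.

Within the data shown here, compound 2 `CC(C)OC(=O)N1CCC(Oc2ncnc3c2CCN3c2ccc(C#N)cn2)CC1` holds the highest of the two numbers so far in a functional assay on CHO-K1 cells with Glucose-dependent insulinotropic receptor (Homo sapiens) as the target, read by a luciferase reporter, with a stated time of 5 h; on this read-out lower numbers stand for smaller maximal responses and higher numbers for larger maximal responses: compound 2 gives 105%, while compound 1 `CC(C)OC(=O)N1CCC(Oc2ncnc3c2CCN3c2ccc(S(C)(=O)=O)cc2F)CC1` gives 91%. Among the measured compounds shown here, the single measured step, a number 14 percentage points higher from compound 1 to compound 2 (beyond the scatter), put 5-cyanopyridin-2-yl in place of 2-fluoro-4-(methylsulfonyl)phenyl on a nitrogen on an aromatic ring in a ring.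

Compound 3 `CC(C)OC(=O)N1CCC(Oc2ncnc3c2CCN3c2ccc([S+]([O-])N(C)C)cc2)CC1` changes the same position once more: a group of 11 heavy atoms (8 carbon, 1 nitrogen, 1 oxygen, 1 sulfur; one six-membered aromatic ring of carbon only) in place of a group of 8 heavy atoms (6 carbon, 2 nitrogen; one six-membered aromatic ring with 1 hetero atom), on a nitrogen on an aromatic ring in a ring. The entering group, like the 2-fluoro-4-(methylsulfonyl)phenyl of compound 1 and unlike the 5-cyanopyridin-2-yl of compound 2, is built on a six-membered aromatic ring of carbon only. For the measured compounds named here, the only step that bears on this change is a number 14 percentage points higher from compound 1 to compound 2 (beyond the scatter); read in the reverse sense it points to a modest drop, though the new group is not the one measured. In this assay compound 3 is therefore expected to give 95%, within a range from 80% to 108%, which is an estimated step of a number 10 percentage points lower from compound 2 to compound 3 (within the scatter).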

Compound 3, largest response reached (reported as percent of maximum), in percent of the reference or control that the assay uses: 128%
Compound 3: the middle estimate sits 33 percentage points below what was measured, outside the stated range (above it).
By their numbers in this assay, from the lowest: compound 1; then compound 2; then compound 3.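

A six-membered aromatic ring of carbon only does not by itself hold the response down at this place on the nitrogen: the change gives a number 23 percentage points higher from compound 2 to compound 3 (beyond the scatter) in this assay and thus reverses the direction suggested by the earlier pair. Within the carbon-only rings the spread is wider still, with a number 37 percentage points higher from compound 1 to compound 3 (beyond the scatter) as the largest step in the series. Ring type alone therefore does not set the order, as compound 1 and compound 3 share it yet lie at the two ends, with the 5-cyanopyridin-2-yl of compound 2 in the middle. No measurement on hand accounts for these rises.

Going by these compounds, compound 1 and compound 3 differ in both the fluorine and the sulfur-bearing group, so the contribution of each stays open. Also open, on these data alone, is whether a phenyl ring carrying an amine or a carboxylic acid in place of the sulfur-bearing group would keep this response.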